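The source may hold more compounds than are shown below. What is called first, only, known or untested is meant among the compounds shown, and "the series" means these compounds.

Measured compounds in a functional assay on PC-3 cells (Homo sapiens) for cytotoxicity, read by MTT assay, with a stated time of 72 h; a lower number here means a stronger inhibitor, a higher number a weaker inhibitor:
Compound 1 `O=C(Nc1ccc(Oc2ccnc3[nH]ccc23)c(F)c1)c1ccc(-c2ccccc2)cn1` gives 760 nM
Compound 2 `Cc1ccc(-c2ccc(C(=O)Nc3ccc(Oc4ccnc5[nH]ccc45)c(F)c3)nc2)cc1` gives 2640 nM
Compound 3 `O=C(Nc1ccc(Oc2ccnc3[nH]ccc23)c(F)c1)c1ccc(-c2ccc(F)cc2)cn1` gives 13400 nM

Compound 3 stands highest of the three numbers in this assay: there is a 5.1-fold higher number from compound 2 to compound 3 (0.71 log units; beyond the scatter) and an 18-fold higher number from compound 1 to compound 3 (1.25 log units; beyond the scatter), both beyond the scatter, so compound 3 is the weakest of the measured set. Compound 4 `O=C(Nc1ccc(Oc2ccnc3[nH]ccc23)c(F)c1)c1ccc(-c2ccc(F)cc2F)cn1` differs from compound 3 by fluoro in place of hydrogen on an aromatic carbon; the same difference, cut one bond further out, reads 4-fluorophenyl to 2,4-difluorophenyl.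

For the measured compounds named here, only one measured step is of the same kind, a fluoro in place of hydrogen on an aromatic carbon, and that step, from compound 1 to compound 3, was large and weakening. The step from compound 1 to compound 2 and the step from compound 2 to compound 3 concern a methyl and bear on it less directly. A second fluoro on the same ring is expected to push the number further up, though likely by less than the first did, and with wide uncertainty. Compound 4 is therefore estimated at 25000 nM, with a range of 8000 nM to 80000 nM. The step expected is a 1.9-fold higher number from compound 3 to compound 4 (0.27 log units; within the scatter).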

Compound 4, half-maximal inhibitory concentration: 4720 nM
Compound 4: the middle estimate sits 5.3-fold (0.72 log units) above what was measured; measured number below the stated range.
By their numbers in this assay, from the lowest: compound 1; then compounds 2 and 4 (each within the scatter of the next); then compound 3.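

In this assay the second fluoro, ortho to a large group and meta to a fluoro group, gives a 2.8-fold lower number from compound 3 to compound 4 (0.45 log units; beyond the scatter) and so runs opposite to the first fluoro on this ring, which gave an 18-fold higher number from compound 1 to compound 3 (1.25 log units; beyond the scatter). Across these compounds, then, a fluoro on this ring does not act in one direction: what it does differs with the place it takes. The 2,4-difluorophenyl group recovers only part of the loss, since a 6.2-fold higher number from compound 1 to compound 4 (0.79 log units; beyond the scatter) remains relative to the plain phenyl, while a 1.8-fold higher number from compound 2 to compound 4 (0.25 log units; within the scatter) leaves it not distinguished from 4-methylphenyl.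

On these data alone, whether a single fluoro ortho to a large group, as in 2-fluorophenyl, would act the same way without the 4-fluoro, or whether a chloro or a methoxy would do so in that place, stays open. Nothing shown here accounts for the reversal.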